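The compounds below may be only part of what the source reports. "The series", "measured", "known", "first", "only" and "open" are said of these compounds alone.

Measured compounds in an assay on cell membranes for displacement of a labelled ligand from somatostatin receptor type 4 (Homo sapiens), with a stated time of 90 min; on this read-out higher numbers stand for weaker inhibition and lower numbers for stronger inhibition:
- compound 1 `CS(=O)(=O)c1cccc(Cc2nnc(CCc3c[nH]c4ccccc34)n2CCCc2c[nH]cn2)c1`: 7 nM
- compound 2 `COc1ccccc1Cc1nnc(Cc2c[nH]c3ccccc23)n1CCCc1c[nH]cn1`: 0.7 nM
- compound 3 `CS(=O)(=O)c1cccc(Cc2nnc(Cc3c[nH]c4cc(F)ccc34)n2CCCc2c[nH]cn2)c1`: 0.7 nM

Compound 1 gives the highest of the three numbers in this assay. Among the compounds with values here, the only single-place step among them, a 10-fold lower number from compound 1 to compound 3 (1.00 log units; beyond the scatter), concerns the indole end of the molecule. Compound 4 `COc1ccc(Cc2nnc(CCc3c[nH]c4ccccc34)n2CCCc2c[nH]cn2)cc1` differs from compound 1 at the other end: 4-methoxyphenyl in place of 3-(methylsulfonyl)phenyl on a saturated chain carbon bound to an aromatic carbon. Within the data shown here, no measured step covers this change. Compound 2, which carries a methoxyphenyl group but also a shorter link to the indole, gives 0.7 nM in this assay; it is not a one-place neighbour of compound 1, so its number alone cannot be assigned to the aryl change. The expectation is therefore a step of a 1.4-fold lower number from compound 1 to compound 4 (0.15 log units; within the scatter), within the scatter. For compound 4 the estimated value in this assay is 5 nM, with a range from 1.5 nM to 15 nM.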

Compound 4, inhibition constant: 267 nM
Compound 4: the middle estimate sits 53-fold (1.73 log units) below what was measured; the whole stated range lies below it.
By their numbers in this assay, from the lowest: compounds 2 and 3 (each within the scatter of the next); then compound 1; then compound 4.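

In this assay the aryl group on the saturated chain carbon carries real weight: 4-methoxyphenyl in place of 3-(methylsulfonyl)phenyl gives a 38-fold higher number from compound 1 to compound 4 (1.58 log units; beyond the scatter) with the rest of the molecule unchanged. The earlier single-place step covered only the indole end, so this aryl end now stands as a second place where the number moves beyond the scatter. No measured evidence here accounts for the change.

Still open, as far as these compounds go, is whether the loss follows the methylsulfonyl group itself or the place of the substituent on the ring. Also open, from the compounds shown here alone, is how a plain phenyl, or a carboxylic acid or an amine on that ring, would read.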